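The compounds below may be only part of what the source reports. "The series", "measured", "known", "first", "only" and "open" are said of these compounds alone.

Two stereoisomers anchor the series. In an ADME assay on Vero cells (Chlorocebus sabaeus) for cytotoxicity (on this read-out higher numbers stand for weaker inhibition and lower numbers for stronger inhibition), compound 1 (`C=C/C=C\[C@H](C)[C@H](OC(N)=O)[C@@H](C)[C@H](O)[C@@H](C)C[C@@](C)(O)[C@H]1[C@H](C)[C@@H](O)[C@@H](C)[C@@H]1/C=C/C[C@@H]1OC(=O)[C@H](C)[C@@H](O)[C@H]1C`) gives 4300 nM, and compound 2 (`C=C/C=C\[C@H](C)[C@H](OC(N)=O)[C@@H](C)[C@H](O)[C@@H](C)C[C@](C)(O)[C@H]1[C@H](C)[C@@H](O)[C@@H](C)[C@@H]1/C=C/C[C@@H]1OC(=O)[C@H](C)[C@@H](O)[C@H]1C`) gives 16600 nM, the higher of the two numbers and so the weaker inhibition. Going by the values given here, the one measured step is a 3.9-fold higher number from compound 1 to compound 2 (0.59 log units; beyond the scatter), a modest shift beyond the scatter, and it is traced to the fact that compounds 1 and 2 differ only in the configuration as drawn.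

Compound 3 (`C=C/C=C\[C@H](C)[C@H](OC(N)=O)[C@@H](C)[C@H](O)[C@H](C)C[C@](C)(O)[C@H]1[C@H](C)[C@@H](O)[C@@H](C)[C@@H]1/C=C/C[C@@H]1OC(=O)[C@H](C)[C@@H](O)[C@H]1C`) has not yet been measured. Its change relative to compound 2 is the two compounds have the same atoms and bonds and differ only in configuration as drawn: 1 of 17 stereo elements differ; a stereocentre at a saturated chain carbon is drawn S in compound 2 and R in compound 3; nothing leaves and nothing enters. Among the compounds with values here, the measured step is the only precedent, as it too is a change of drawn configuration at a saturated chain carbon. A single step gives a size but fixes no direction for another such change. Resting on a 3.9-fold higher number from compound 1 to compound 2 (0.59 log units; beyond the scatter), a modest change of no greater size is expected in this assay, leaning towards a lower number, with the opposite direction not excluded. The estimated move is a 1.7-fold lower number from compound 2 to compound 3 (0.22 log units; within the scatter). Compound 3 is expected at 10000 nM, with an estimated range from 3500 nM to 30000 nM.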

Compound 3, half-maximal inhibitory concentration: 11400 nM
For compound 3 the middle estimate is 1.1-fold (0.06 log units) below the measured one; low and high end bracket the measured number.
By their numbers in this assay, from the lowest: compound 1; then compounds 3 and 2 (each within the scatter of the next).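

Reversing the drawn configuration at this saturated chain carbon leaves no resolved effect on the background of compound 2: in this assay, the result is a 1.5-fold lower number from compound 2 to compound 3 (0.16 log units; within the scatter). The earlier single-centre change, a 3.9-fold higher number from compound 1 to compound 2 (0.59 log units; beyond the scatter), lay beyond the scatter, so in this small set the two saturated chain carbons do not behave alike. With two stereo elements changed at once, the separation from the first stereoisomer remains, at a 2.7-fold higher number from compound 1 to compound 3 (0.42 log units; beyond the scatter), and the only structural difference available to account for it is stereochemical: the fact that compounds 1 and 3 differ only in the configuration as drawn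

The compounds shown do not tell how much of that separation belongs to each centre, or whether the second centre would also give no resolved effect on the background of compound 1. Going by these compounds, all three share the same atoms and bonds, so how a different group at either of these chain carbons, such as an amine or a longer chain, would read in this assay remains open.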